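This account rests on a few compounds, and the source may have more. Where it says the series, first, only, none or still open, it means among the compounds named here.

Measured so far in an assay on a protein complex for inhibition of ubiquitin carboxyl-terminal hydrolase 1/WD repeat-containing protein 48 (Homo sapiens), read by fluorescence; a higher number here means a weaker inhibitor, a lower number a stronger inhibitor: compound 1 `Cc1cnc(-c2ccccc2C2CC2)nc1NCc1ccc(-c2cccnc2)cc1` gives 180 nM; compound 2 `Cc1cnc(-c2ccccc2CO)nc1NCc1ccc(-c2cccnc2)cc1` gives 10500 nM.

Compound 2 stands highest of the two numbers in this assay; its nearest neighbour is compound 1, and the step of a 58-fold higher number from compound 1 to compound 2 (1.77 log units; beyond the scatter) shows how strongly this position responds. Compound 3 `CC(=O)c1ccccc1-c1ncc(C)c(NCc2ccc(-c3cccnc3)cc2)n1` differs from compound 2 by acetyl in place of hydroxymethyl on an aromatic carbon. Among the compounds with values here, only that one measured step bears on the change, and it concerns a different entering group, so the direction is uncertain. Given the sensitivity seen, a partial recovery is expected: the step of a 3.5-fold lower number from compound 2 to compound 3 (0.54 log units; beyond the scatter) is the estimate. Compound 3 is expected at 3000 nM, within 500 nM to 15000 nM.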

Compound 3, half-maximal inhibitory concentration: 8700 nM
The estimate for compound 3 lay 2.9-fold (0.46 log units) below the measured number; measured number inside the range.
By their numbers in this assay, from the lowest: compound 1; then compounds 3 and 2 (each within the scatter of the next).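

Exchanging hydroxymethyl, which has a hydrogen-bond donor, for acetyl, which has none, gives only a 1.2-fold lower number from compound 2 to compound 3 (0.08 log units; within the scatter) in this assay, so losing that donor does not separate these two groups at this position. Cyclopropyl remains apart from both oxygen-containing groups, as acetyl also shows with a 48-fold higher number from compound 1 to compound 3 (1.68 log units; beyond the scatter). No measurement here explains either result. Open, going by these compounds, is whether an ethyl group, which contains no oxygen, would give a number close to that of compound 1. On these data alone, the response to an amine or a carboxylic acid at this position also remains open.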